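A Single Methyl on the Amine of Compound 3

A few compounds are considered here, and "the series" means these few. Any claim that something is new, unique, unknown or untested is made for them only; others in the source may bear on it.

In a functional assay on HL-60 cells (Homo sapiens) for cytotoxicity, read by MTT assay, with a stated time of 96 h (on this read-out lower numbers stand for stronger inhibition and higher numbers for weaker inhibition), compound 3 `CC[C@H](N)C(=O)N[C@@H]1C(=O)N2[C@@H](CC[C@@H]1CCNC(=O)NCc1ccccc1)CC[C@H]2C(=O)NC(c1ccccc1)c1ccccc1` gives 83300 nM. That lies within the usual scatter of compound 1 `CC[C@H](NC)C(=O)N[C@@H]1C(=O)N2[C@@H](CC[C@@H]1CN)CC[C@H]2C(=O)NC(c1ccccc1)c1ccccc1` at 51800 nM, while compound 2 `CC[C@H](NC)C(=O)N[C@@H]1C(=O)N2[C@@H](CC[C@@H]1CCNC(=O)c1ccccc1)CC[C@H]2C(=O)NC(c1ccccc1)c1ccccc1` at 32600 nM shows a lower number, beyond the scatter from compound 3. All three therefore sit in the same broad range, with only this one gap exceeding the scatter.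

Compound 4 `CC[C@H](NC)C(=O)N[C@@H]1C(=O)N2[C@@H](CC[C@@H]1CCNC(=O)NCc1ccccc1)CC[C@H]2C(=O)NC(c1ccccc1)c1ccccc1` differs from compound 3 by one small edit: methyl in place of hydrogen on an amine nitrogen, which turns amino into methylamino (methyl in place of hydrogen on an amine nitrogen). Among the measured compounds shown here, no measured step covers this exact change. For the measured compounds named here, the only measured step, a 1.6-fold lower number from compound 1 to compound 2 (0.20 log units; within the scatter), swaps amino for benzamidomethyl, a different edit, and it is no larger than the scatter. Indirect evidence comes from the methylamino group that compound 4 would share with compound 1 at 51800 nM and compound 2 at 32600 nM, although these two also differ from compound 4 in other groups. Those values suggest a modest move in this assay toward a lower number, and the expected size is a 1.7-fold lower number from compound 3 to compound 4 (0.22 log units; within the scatter). For compound 4 the estimate is 50000 nM, with an expected range of 20000 nM to 100000 nM.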

Compound 4, half-maximal inhibitory concentration: 52200 nM
Compound 4: the middle estimate sits 1.0-fold (0.02 log units) below what was measured, within the range that was stated.
By their numbers in this assay, from the lowest: compounds 2, 1, 4 and 3 (each within the scatter of the next, the first and the last beyond it).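

In this assay, among the compounds shown here, the step (a 1.6-fold lower number from compound 3 to compound 4 (0.20 log units; within the scatter)) gives the first direct reading of methyl in place of hydrogen on this amine nitrogen, and it shows that turning 1-aminopropyl into 1-(methylamino)propyl does not carry the number beyond the scatter. With the methylamino group in place, the two other edits also stay within the scatter: benzylamino in place of phenyl on a carbonyl carbon (a 1.6-fold higher number from compound 2 to compound 4 (0.20 log units; within the scatter)), and ((benzylcarbamoyl)amino)methyl in place of amino on a saturated chain carbon bound to a saturated ring carbon (a 1.0-fold higher number from compound 1 to compound 4 (0.00 log units; within the scatter)). No separate measurement bears on these results, so the numbers alone describe them and nothing here accounts for them.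

Still open, going by these compounds, is whether a larger change on the same amine nitrogen, such as an ethyl group, a dimethylamino group or an acetyl group, would produce a step beyond the scatter. For the compounds shown here, the methyl edit is also read on only one pair of compounds, so its size with benzamidomethyl or a plain amine on the other chain remains unknown.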